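The compounds below may be only part of what the source reports. "The series", "measured", "known", "first", "only" and "open" are said of these compounds alone.

Going by the values given here, in a functional assay on DLD-1 cells (Homo sapiens) for cytotoxicity, read by MTT assay, with a stated time of 48 h (a higher number here means a weaker inhibitor, a lower number a stronger inhibitor), compound 3 `CCOc1ccc2c(NCCN(C)C)ccnc2c1` gives 6240 nM, the highest of the three numbers measured so far. Compound 2 `CCOc1ccc2c(Cl)ccnc2c1` gives 2750 nM in this assay, and compound 1 `CCCCCCOc1ccc2c(NCCN(C)C)ccnc2c1` gives 1870 nM. Two single-point steps lead to compound 3: a 3.3-fold higher number from compound 1 to compound 3 (0.52 log units; beyond the scatter), where a butyl group is dropped from the chain that hangs on the aromatic oxygen, and a 2.3-fold higher number from compound 2 to compound 3 (0.36 log units; beyond the scatter), where the chloro group is swapped for the (2-(dimethylamino)ethyl)amino group.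

The next compound, compound 4 `CN(C)CCNc1ccnc2cc(OCc3ccccc3)ccc12`, differs from compound 3 in one place: phenyl in place of methyl on a saturated chain carbon bound to an oxygen on an aromatic ring. Among the compounds with values here, of the measured steps, only the one from compound 1 to compound 3 touches the same part of the molecule, since it also changes a saturated chain carbon of the group on the aromatic oxygen; there the compound with the larger chain carried the lower number. Compound 4 again adds carbon to that chain, so the expectation is a lower number than compound 3, of a similar modest size, estimated as a 3.1-fold lower number from compound 3 to compound 4 (0.49 log units; beyond the scatter). Because compound 1 stands at 1870 nM, the estimate for compound 4 is 2000 nM, with a likely range from 800 nM to 5000 nM.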

Compound 4, half-maximal inhibitory concentration: 2140 nM
Compound 4: the middle estimate sits 1.1-fold (0.03 log units) below what was measured; the measured number falls inside the stated range.
By their numbers in this assay, from the lowest: compounds 1, 4 and 2 (each within the scatter of the next); then compound 3.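

In this assay, going by these compounds alone, a 2.9-fold lower number from compound 3 to compound 4 (0.46 log units; beyond the scatter) shows that the end of the group on the aromatic oxygen can carry an aromatic ring, whereas the earlier compounds showed only a saturated chain there. The phenyl group also does about as well as the pentyl group it can be compared with: a 1.1-fold higher number from compound 1 to compound 4 (0.06 log units; within the scatter) leaves compound 1 and compound 4 within the scatter of each other, so these two quite different groups cannot be told apart in this measurement, and both give a lower number than the methyl group of compound 3. Nothing measured here gives a reason for these numbers.

On these data alone, it stays open whether a saturated ring such as cyclohexyl, a phenyl ring carrying a fluoro or methoxy group, or a chain ending in an amine or a carboxylic acid would fit the same place and move the number further. Within the data shown here, the swap between chloro and (2-(dimethylamino)ethyl)amino is also seen only with ethoxy on the oxygen, and how it reads with benzyloxy remains unknown.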